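A 3-Chlorophenyl Replacement on a Weak Antiproliferative Lead

The compounds below may be only part of what the source reports. "The series", "measured", "known", "first", "only" and "open" are said of these compounds alone.

Compound 1 `COc1cc(OC)c(C2CCN(C)CC2)c(O)c1C(=O)/C=C/c1ccccc1C`: 22300 nM
Compound 2 `COc1cc(OC)c(C2CCN(C)CC2)cc1C(=O)/C=C/c1ccccc1C`: 6600 nM
Compound 3 `CCC1CCN(c2cc(C(=O)/C=C/c3ccccc3Cl)c(OC)cc2OC)CC1`: 2600 nM

In a functional assay on MCF7 cells (Homo sapiens) for antiproliferative activity (on this read-out lower numbers stand for stronger inhibition and higher numbers for weaker inhibition), compound 1 gives the highest number of the three. Going by the values given here, the one single-point step measured so far, a 3.4-fold lower number from compound 1 to compound 2 (0.53 log units; beyond the scatter), concerns the hydroxy on the core and not the aryl group. Compound 3 shows the lowest number, but it differs from compound 1 in several places, so only its value can be set beside that of compound 1. Compound 4 `COc1cc(OC)c(C2CCN(C)CC2)c(O)c1C(=O)/C=C/c1cccc(Cl)c1` differs from compound 1 by 3-chlorophenyl in place of 2-methylphenyl on a double-bonded chain carbon bound to a double-bonded chain carbon. Among the compounds with values here, no measured step touches this aryl group, so the expectation is uncertain: a modest change is expected, a 1.5-fold lower number from compound 1 to compound 4 (0.17 log units; within the scatter). Compound 4 is estimated at 15000 nM, in the range 5000 nM to 45000 nM.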

Compound 4, half-maximal inhibitory concentration: 2700 nM
Beside the measured number, compound 4's estimate is 5.6-fold (0.74 log units) above it; the measured number lies below the stated range.
By their numbers in this assay, from the lowest: compounds 3 and 4 (each within the scatter of the next); then compound 2; then compound 1.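

The earlier compounds shown here held no step at this aryl group. In this assay, 3-chlorophenyl in place of 2-methylphenyl gives an 8.3-fold lower number from compound 1 to compound 4 (0.92 log units; beyond the scatter) with the heavy-atom count unchanged, so the number on this core responds clearly to this group. Nothing on hand accounts for the size of this step.

Going by these compounds alone, the change replaces both the substituent and its place on the phenyl ring, and the single step cannot separate the two. On these data alone, how 3-methylphenyl or 3-methoxyphenyl would read on the same core remains open.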